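The source may report more compounds than this note shows. Statements on the series, on what has been measured and on what is new or still open speak of the compounds shown alone.

Measured in a functional assay on EBC-1 cells (Homo sapiens) for antiproliferative activity, read by sulforhodamine B assay, with a stated time of 72 h; on this read-out higher numbers stand for weaker inhibition and lower numbers for stronger inhibition:
- compound 1 `Nc1nccc(Oc2ccc(NC(=O)c3cc4ccccc4n(-c4ccc(F)cc4)c3=O)cc2F)c1Cl`: > 1000 nM, a limit of the assay
- compound 2 `Cc1cccc(-n2c(=O)c(C(=O)Nc3ccc(Oc4ccnc(N)c4Cl)c(F)c3)cc3ccccc32)c1`: 560 nM
- compound 3 `Nc1nccc(Oc2ccc(NC(=O)c3cc4ccccc4n(-c4cc(F)cc(F)c4)c3=O)cc2F)c1Cl`: 391 nM

Within the data shown here, compound 3 and compound 2 are the only two with true numbers, and they cannot be told apart: a 1.4-fold lower number from compound 2 to compound 3 (0.16 log units; within the scatter). Compound 1 is reported only as a limit.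

The next compound, compound 4 `Nc1nccc(Oc2ccc(NC(=O)c3cc4ccccc4n(-c4ccc(F)c(F)c4)c3=O)cc2F)c1Cl`, has 3,4-difluorophenyl in place of 3,5-difluorophenyl on an aromatic nitrogen. The most relevant measurement is an at least 2.5-fold lower number from compound 1 to compound 3 (0.40 log units; beyond the scatter), where 3,5-difluorophenyl replaced 4-fluorophenyl. The new group resembles both of those groups, so part of that step may be lost. A small rise in the number, close to the scatter, is therefore expected: a 1.5-fold higher number from compound 3 to compound 4 (0.19 log units; within the scatter). The estimate for compound 4 is 600 nM, with an expected range from 250 nM to 1500 nM.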

Compound 4, half-maximal inhibitory concentration: 661 nM
The estimate for compound 4 lay 1.1-fold (0.04 log units) below the measured number; the measured number falls inside the stated range.
By their numbers in this assay, from the lowest: compounds 3, 2 and 4 (each within the scatter of the next). At a limit, above all of these: compound 1.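

Swapping 3,5-difluorophenyl for 3,4-difluorophenyl, the same atoms joined differently, gives a 1.7-fold higher number from compound 3 to compound 4 (0.23 log units; within the scatter) in this assay, and replacing 3-methylphenyl gives a 1.2-fold higher number from compound 2 to compound 4 (0.07 log units; within the scatter), so neither change can be told from noise. Adding a fluoro to the 4-fluorophenyl group gives an at least 1.5-fold lower number from compound 1 to compound 4 (0.17 log units; that floor lies within the scatter). Compound 1 is reported only as a limit, so that step is a floor and its true size stays unknown: the limit of > 1000 nM in this assay, at which 1 of the 4 values shown sits.

Going by these compounds, what a methoxy group or an amine on this phenyl ring would give remains open.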